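Exchanging the Aryl Group for a Pyridyl Ring

The source may report more compounds than this note shows. Statements on the series, on what has been measured and on what is new or still open speak of the compounds shown alone.

Of the compounds shown here, three sharing one core have been measured in a functional assay on CHO cells with adenosine receptor A1 (Homo sapiens) as the target, read by cAMP accumulation and immunoassay, with a stated time of 6 min, tested at 0.1 uM; a higher number here means a weaker effect of the compound at the concentration tested, a lower number a stronger effect. Compound 1 `Nc1scc(CN2CCN(c3cc(Cl)cc(Cl)c3)CC2)c1C(=O)c1ccc(Cl)cc1` gives -22%, compound 2 `COc1ccc(N2CCN(Cc3csc(N)c3C(=O)c3ccc(Cl)cc3)CC2)cc1` gives 0%, and compound 3 `Nc1scc(CN2CCN(c3cccc(C(F)(F)F)c3)CC2)c1C(=O)c1ccc(Cl)cc1` gives -30%. On these numbers compound 3 carries the lowest value, although its gap to compound 1 lies within the scatter, while compound 2 sits clearly higher. Compound 4 `Nc1scc(CN2CCN(c3cccnc3)CC2)c1C(=O)c1ccc(Cl)cc1` differs from compound 3 in one place: pyridin-3-yl in place of 3-(trifluoromethyl)phenyl on an amine nitrogen in a ring. The steps measured so far all exchange the aryl group on the same ring nitrogen: a number 22 percentage points higher from compound 1 to compound 2 (beyond the scatter), a number 8 percentage points lower from compound 1 to compound 3 (within the scatter) and a number 30 percentage points lower from compound 2 to compound 3 (beyond the scatter). Within the data shown here, none of them introduces a pyridin-3-yl group, so there is no direct precedent; what they show is that the two aryl groups bearing chlorine or trifluoromethyl read close together, whereas the 4-methoxyphenyl group reads weaker. Among the measured compounds shown here, with no measured counterpart for the pyridin-3-yl group, a modest move toward the weaker end is expected, a number 20 percentage points higher from compound 3 to compound 4 (beyond the scatter). Compound 4 is therefore estimated at -10%, within a range from -35% to 15%.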

Compound 4, a percentage reported as activity, at one concentration (the size of the read-out at that concentration, not a potency): 3.4%
Compound 4: the middle estimate sits 13.4 percentage points below what was measured; the measured number falls inside the stated range.
By their numbers in this assay, from the lowest: compounds 3 and 1 (each within the scatter of the next); then compounds 2 and 4 (each within the scatter of the next).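

In this assay, among these compounds, the pyridin-3-yl group is the first ring with a hetero atom on this amine nitrogen, and it gives a number 33.4 percentage points higher from compound 3 to compound 4 (beyond the scatter) as a large step, while a number 25.4 percentage points higher from compound 1 to compound 4 (beyond the scatter) is a modest one. With a number 3.4 percentage points higher from compound 2 to compound 4 (within the scatter), the pyridin-3-yl and 4-methoxyphenyl compounds fall together, so the four compounds split into two pairs, with the 3,5-dichlorophenyl and 3-(trifluoromethyl)phenyl compounds forming the other pair. Nothing measured here accounts for this split.

As far as these compounds go, whether pyridin-2-yl or pyridin-4-yl would read like pyridin-3-yl remains open. So does whether a pyridine ring carrying a trifluoromethyl group or a chlorine would stay with compound 4 or move toward compound 3.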